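One Fluorine Added to the Benzoyl Ring

The source may hold more compounds than are shown below. What is called first, only, known or untested is meant among the compounds shown, and "the series" means these compounds.

Measured compounds:
compound 1, `O=C(N/N=C/c1c(-c2cc3ccccc3oc2=O)[nH]c2ccccc12)c1cccc(Br)c1`, > 200000 nM
compound 2, `O=C(N/N=C/c1c(-c2cc3ccc(Br)cc3oc2=O)[nH]c2ccccc12)c1ccccc1`, 9100 nM

In a functional assay on MCF7 cells (Homo sapiens) for inhibition, read by MTT assay, with a stated time of 48 h (a higher number here means a weaker inhibitor, a lower number a stronger inhibitor), compound 2 gives 9100 nM, the only plain number among the results shown. For compound 1 the result is a limit of the assay, > 200000 nM, not a measured number. the limit of > 200000 nM in this assay, at which 1 of the 2 values shown sits, marks where compound 1 sits, so the two cannot be compared as a step of known size.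

Compound 3, `O=C(N/N=C/c1c(-c2cc3ccc(Br)cc3oc2=O)[nH]c2ccccc12)c1ccccc1F`, differs from compound 2 in a single place: fluoro in place of hydrogen on an aromatic carbon. Going by the values given here, no pair of measured compounds differs in this way, so there is no measured step to lean on. The step of a 1.0-fold lower number from compound 2 to compound 3 (0.00 log units; within the scatter) is expected to stay within the usual scatter of repeated measurements, with no direction favoured. On that basis compound 3 is estimated at 9000 nM, with a range from 3000 nM to 30000 nM.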

Compound 3, half-maximal inhibitory concentration: > 200000 nM
Compound 3: only a limit was reported; the forecaster's own chance of this, stated with the estimate: 10%; middle value at least 22-fold (1.34 log units) away from the limit.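

In this assay, a single fluoro in place of hydrogen on an aromatic carbon, ortho to a large group, gives an at least 21-fold higher number from compound 2 to compound 3 (1.34 log units; beyond the scatter), so this position of the benzoyl ring does not accept every change, even one of 1 heavy atom. Compound 3 gives > 200000 nM, which is a limit of the assay and not a number, so the step has a lower bound but no known size. Compound 3 now stands at the same limit as compound 1: the limit of > 200000 nM in this assay, at which 2 of the 3 values shown sit.

The compounds shown do not tell whether the loss belongs to fluoro itself or would follow any group at this carbon, a question that a chloro, a methoxy or an amine there could help to settle. They also give no reason for the loss, and they leave open how fluoro would fare on another carbon of the same ring.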